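Taking the Allyl Group Off Compound 2

The source may hold more compounds than are shown below. What is called first, only, known or untested is meant among the compounds shown, and "the series" means these compounds.

In a functional assay on REH cells (Homo sapiens) for cytotoxicity, read by resazurin assay, with a stated time of 72 h (on this read-out higher numbers stand for weaker inhibition and lower numbers for stronger inhibition), compound 1 (`COc1cc(OC)c(C(=O)/C=C/c2ccccc2)c(OC)c1`) gives no number, only a limit of > 20000 nM.

Within the data shown here, compound 2 (`C=CCOc1ccccc1Cc1c(OC)cc(OC)c(C(=O)/C=C/c2ccccc2)c1OC`) carries a 2-(allyloxy)benzyl group on the core of compound 1, and compound 2 gives 12600 nM, the only true number so far. Compound 3 (`COc1cc(OC)c(C(=O)/C=C/c2ccccc2)c(OC)c1Cc1ccccc1O`), not yet measured, has hydrogen in place of allyl on an oxygen on an aromatic ring, turning 2-(allyloxy)benzyl into 2-hydroxybenzyl: hydrogen in place of allyl on an oxygen on an aromatic ring.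

Among the measured compounds shown here, the one measured step that bears on this, an at least 1.5-fold lower number from compound 1 to compound 2 (0.20 log units; that floor lies within the scatter), brought in the whole group at once, so it does not show what the allyl alone adds, and in this assay no change beyond the scatter is expected.

The expected step is a 1.3-fold lower number from compound 2 to compound 3 (0.10 log units; within the scatter).

For compound 3 the estimated value is 10000 nM, with an expected range from 4000 nM to 20000 nM.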

Compound 3, half-maximal inhibitory concentration: > 20000 nM
Compound 3: only a limit was reported (the forecaster's own chance of this, stated with the estimate: 15%); at least 2.0-fold (0.30 log units) between middle value and limit.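

Taking the allyl off the oxygen gives an at least 1.5-fold higher number from compound 2 to compound 3 (0.20 log units; that floor lies within the scatter), so this is the first look at the allyl on its own rather than the whole 2-(allyloxy)benzyl group. The change does not bring the number down, but the size of the rise cannot be told from this floor, which stays within the scatter. In this assay compound 3 gives only a limit, not a true number, which puts it with compound 1: the limit of > 20000 nM in this assay, at which 2 of the 3 values shown sit.

The step from compound 1 to compound 3 cannot be read, as both ends are limits. Still open, from the compounds shown here alone, is whether a different group on this oxygen, such as methyl, propyl with its saturated chain, or a longer chain ending in an amine, would give a true number, and how it would compare with compound 2.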